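The compounds below may be only part of what the source reports. "The series", "measured", "known", "first", "only" and "open" are said of these compounds alone.

Measured in an assay for inhibition of histone deacetylase 4 (Homo sapiens); on this read-out higher numbers stand for weaker inhibition and lower numbers for stronger inhibition:
Compound 1 `Cc1ccc(-c2noc(-c3ccc(C(=O)C(F)(F)F)s3)n2)cc1` gives 110 nM.
Compound 2 `O=C(NCc1ccccc1)c1ccc(C(=O)C(F)(F)F)s1` gives 243 nM.
Compound 3 `O=C(c1ccc(-c2nc(-c3ccc(C(F)(F)F)cc3)no2)s1)C(F)(F)F` gives 200 nM.

The three numbers lie close together: the step of a 1.8-fold higher number from compound 1 to compound 3 (0.26 log units; within the scatter) is within the scatter, and compound 3 and compound 2 differ by even less, so none of the three can be set apart from the others.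

Compound 4 `CC(C)(C)c1ccc(-c2noc(-c3ccc(C(=O)C(F)(F)F)s3)n2)cc1` differs from compound 3 in one place: tert-butyl in place of trifluoromethyl on an aromatic carbon. Within the data shown here, the only measured step that bears on this position is a 1.8-fold higher number from compound 1 to compound 3 (0.26 log units; within the scatter), which stayed within the scatter, so exchanging one group for another at this position is not expected to move the number beyond the scatter here either.

The estimate for compound 4 in this assay is therefore 160 nM, with a range from 60 nM to 450 nM, which means an expected step of a 1.3-fold lower number from compound 3 to compound 4 (0.10 log units; within the scatter).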

Compound 4, half-maximal inhibitory concentration: > 2000 nM
Compound 4: no number, only a limit (the forecaster's own chance of this, stated with the estimate: 2%); middle value at least 12-fold (1.09 log units) away from the limit.
By their numbers in this assay, from the lowest: compounds 1, 3 and 2 (each within the scatter of the next, the first and the last beyond it). At a limit, above all of these: compound 4.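

Compound 4 gives a limit of this assay, not a number: the limit of > 2000 nM in this assay, at which 1 of the 4 values shown sits.

Methyl and trifluoromethyl at this position stayed within the scatter of each other, but tert-butyl gives an at least 10-fold higher number from compound 3 to compound 4 (1.00 log units; beyond the scatter) and an at least 18-fold higher number from compound 1 to compound 4 (1.25 log units; beyond the scatter). The position is therefore not indifferent to the group placed there, and one exchange of groups on this ring can move the number beyond the scatter.

The compounds shown do not reveal what sets tert-butyl apart from the other two groups. On these data alone, it remains open whether an ethyl group, a methoxy group or an amine here would behave like methyl or like tert-butyl.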